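Lengthening Methoxy to Butoxy

This account rests on a few compounds, and the source may have more. Where it says the series, first, only, none or still open, it means among the compounds named here.

In an ADME assay on L6 cells (Rattus norvegicus) for cytotoxicity, read by resazurin assay, with a stated time of 72 h (on this read-out lower numbers stand for stronger inhibition and higher numbers for weaker inhibition), compound 1 `O=C(NC(=O)c1ccccc1O)c1ccc([N+](=O)[O-])cc1` gives 53 ug/mL and compound 2 `COc1ccc(C(=O)NC(=O)c2ccccc2O)cc1` gives 39 ug/mL so these two values lie within the usual scatter of each other, and neither stands apart. Within the data shown here, the only measured step is a 1.4-fold lower number from compound 1 to compound 2 (0.13 log units; within the scatter) with methoxy in place of nitro on an aromatic carbon. Compound 3 `CCCCOc1ccc(C(=O)NC(=O)c2ccccc2O)cc1` keeps the core of compound 2 and alters its chain: propyl in place of hydrogen on a saturated chain carbon bound to an oxygen on an aromatic ring places propyl in place of hydrogen on a saturated chain carbon bound to an oxygen on an aromatic ring, turning methoxy into butoxy. Among the measured compounds shown here, the measured step involved a different swap and no measured pair lengthens a chain, so it offers only weak guidance. In this assay a small move is therefore expected, probably no larger than the scatter and perhaps slightly downward. The expected change is a 1.3-fold lower number from compound 2 to compound 3 (0.11 log units; within the scatter) as an estimate only. In this assay the expected value for compound 3 is 30 ug/mL with an estimated range from 10 ug/mL to 70 ug/mL around it.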

Compound 3, half-maximal inhibitory concentration: 13 ug/mL
Compound 3: the middle estimate sits 2.3-fold (0.36 log units) above what was measured; measured number inside the range.
By their numbers in this assay, from the lowest: compound 3; then compounds 2 and 1 (each within the scatter of the next).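

Lengthening methoxy to butoxy produces the first change beyond the usual scatter in this assay (a 3.0-fold lower number from compound 2 to compound 3 (0.48 log units; beyond the scatter)). Swapping the nitro group for butoxy also moves the number beyond the scatter (a 4.1-fold lower number from compound 1 to compound 3 (0.61 log units; beyond the scatter)), whereas methoxy in that place stays within it (a 1.4-fold lower number from compound 1 to compound 2 (0.13 log units; within the scatter)), so among these three compounds, the length of the chain on the oxygen matters more than the methoxy-for-nitro swap alone suggested. No measurement shown here explains the stronger inhibition that comes with the longer chain.

On these data alone, it remains open whether a still longer chain, such as hexyloxy, would lower the number further, or whether ethoxy or propoxy would already give part of this shift. It is equally unclear whether the shift would survive with an amine or a carboxylic acid at the end of the chain.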